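The compounds below may be only part of what the source reports. "The series", "measured", "known", "first", "only" and "open" are said of these compounds alone.

The measured compounds and their values in an ADME assay for permeability, using PAMPA, with a stated time of 30 min, at pH 7.4 (a higher number here means that the compound crosses the layer faster, a lower number that the compound crosses the layer more slowly), are:

Compound 1, `COc1ccccc1Oc1ccc2c(NCCCNCc3ccco3)ccnc2c1`, gives 317 10^-6 cm/s.
Compound 2, `c1coc(CNCCCNc2ccnc3cc(CC4CCCCC4)ccc23)c1`, gives 23 10^-6 cm/s.
Compound 3, `c1coc(CNCCCNc2ccnc3cc(-c4cccc5ccccc45)ccc23)c1`, gives 237 10^-6 cm/s.

Compound 3 stands second highest of the three numbers in this assay. Its nearest neighbour is compound 1, with a 1.3-fold lower number from compound 1 to compound 3 (0.13 log units; within the scatter), a step that stays within the scatter. Its furthest neighbour is compound 2, with a 10-fold higher number from compound 2 to compound 3 (1.01 log units; beyond the scatter), a large step well beyond the scatter.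

Compound 4, `COc1cccc(Oc2ccc3c(NCCCNCc4ccco4)ccnc3c2)c1`, differs from compound 3 in one place: 3-methoxyphenoxy in place of naphthalen-1-yl on an aromatic carbon.

For the measured compounds named here, the step that bears most directly on this change is the one from compound 1 to compound 3, where a 2-methoxyphenoxy group gave way to naphthalen-1-yl with only a 1.3-fold lower number from compound 1 to compound 3 (0.13 log units; within the scatter), within the scatter. The change to compound 4 runs in the opposite direction and brings in a 3-methoxyphenoxy group, which shares the methoxyphenoxy motif of compound 1. The large step from compound 2 to compound 3 concerns cyclohexylmethyl and does not apply here. The expectation is therefore a step of a 1.2-fold higher number from compound 3 to compound 4 (0.09 log units; within the scatter) in this assay, not beyond the scatter. Compound 4 is estimated at 290 10^-6 cm/s, with a range from 150 10^-6 cm/s to 560 10^-6 cm/s.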

Compound 4, apparent permeability: 317 10^-6 cm/s
Beside the measured number, compound 4's estimate is 1.1-fold (0.04 log units) below it; the range from low to high includes it.
By their numbers in this assay, from the lowest: compound 2; then compounds 3, 1 and 4 (each within the scatter of the next).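

In this assay the exchange of 2-methoxyphenyl for 3-methoxyphenyl on the oxygen gives no change at the digits printed from compound 1 to compound 4 (within the scatter) and so shows no sensitivity to where the methoxy group sits in this pair. The exchange of naphthalen-1-yl for 3-methoxyphenoxy gives a 1.3-fold higher number from compound 3 to compound 4 (0.13 log units; within the scatter) even though the entering group has one aromatic ring in place of two and 2 hydrogen-bond acceptors in place of 0, so this position tolerates both kinds of group without a change beyond the scatter. For the compounds shown here, with a 14-fold higher number from compound 2 to compound 4 (1.14 log units; beyond the scatter) as a second large step, cyclohexylmethyl in compound 2 remains the only group here that stands apart, while compounds 1, 3 and 4 lie within the scatter of one another. Nothing measured here explains these steps.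

The compounds shown cannot tell whether the gap at compound 2 follows from the loss of the aromatic ring or from the carbon link, which a benzyl or a cyclohexyloxy group on the same aromatic carbon would help to separate. Going by these compounds, it also remains open whether a group carrying an amine or a carboxylic acid at this place would stay with compounds 1, 3 and 4 or fall toward compound 2.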